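Dropping a Methyl Group: What the Data Allow

The source may hold more compounds than are shown below. What is called first, only, known or untested is meant among the compounds shown, and "the series" means these compounds.

Measured so far in a functional assay on BGC-823 cells (Homo sapiens) for cytotoxicity, read by MTT assay; on this read-out lower numbers stand for stronger inhibition and higher numbers for weaker inhibition:
- compound 1, `COc1cccc(/C=C/C(=O)c2sc(Nc3cccc(C)c3)nc2C)c1`, gives only a limit, > 25000 nM, and no number
- compound 2, `Cc1cccc(Nc2nc(C)c(C(=O)/C=C/c3ccccc3Cl)s2)c1`, gives 24200 nM
- compound 3, `Cc1cccc(Nc2nc(C)c(C(=O)/C=C/c3ccccc3)s2)c1`, gives 13600 nM

Compound 2 stands as the highest of the two plain numbers; its nearest neighbour is compound 3, a step of a 1.8-fold lower number from compound 2 to compound 3 (0.25 log units; within the scatter), which is within the scatter. Compound 1 sits at the limit (the limit of > 25000 nM in this assay, at which 1 of the 3 values shown sits). The steps of an at least 1.0-fold lower number from compound 1 to compound 2 (0.01 log units; that floor lies within the scatter) and an at least 1.8-fold lower number from compound 1 to compound 3 (0.26 log units; that floor lies within the scatter) are likewise within the scatter.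

Compound 4, `Cc1nc(Nc2ccccc2)sc1C(=O)/C=C/c1ccccc1Cl`, differs from compound 2 in one place: hydrogen in place of methyl on an aromatic carbon. Within the data shown here, none of the measured steps touches this part of the molecule; all three concern the aryl ring on the double-bonded chain, and none of them moved the read-out beyond the scatter. There is therefore no basis to expect a step in either direction. Compound 4 is expected to show no change beyond the scatter, a step of a 1.0-fold lower number from compound 2 to compound 4 (0.00 log units; within the scatter). Compound 4 is thus estimated at 24000 nM, within a range from 8000 nM to 70000 nM.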

Compound 4, half-maximal inhibitory concentration: 22800 nM
Beside the measured number, compound 4's estimate is 1.1-fold (0.02 log units) above it, within the range that was stated.
By their numbers in this assay, from the lowest: compounds 3, 4 and 2 (each within the scatter of the next). At a limit, above all of these: compound 1.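

The earlier steps shown here all concerned the aryl ring on the double-bonded chain, whereas this one touches a different part of the molecule, turning 3-methylphenyl into phenyl. Replacing that methyl with hydrogen gives a 1.1-fold lower number from compound 2 to compound 4 (0.03 log units; within the scatter), so for this pair the methyl on the six-membered aromatic ring makes no difference that can be read. This result says little about weaker compounds, since the read-out has a ceiling that is a limit and not a number, and compound 1 sits there: the limit of > 25000 nM in this assay, at which 1 of the 4 values shown sits.

The compounds shown leave open whether a larger or different group in this place, such as an amine, a carboxylic acid or a longer chain, would move the read-out. They also leave open whether the same loss of methyl would read the same way on compound 3.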